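This account rests on a few compounds, and the source may have more. Where it says the series, first, only, none or still open, it means among the compounds named here.

Compound 1 `O=Cc1ccc(-c2cn3ccnc3c(-c3ccc4ncn(C5CCCCC5)c4c3)n2)cc1` and compound 2 `CCc1ccc(-c2cn3ccnc3c(-c3ccc4ncn(Cc5ccccc5)c4c3)n2)cc1` share a core. In a functional assay on SK-OV-3 cells (Homo sapiens) for inhibition, read by sulforhodamine B assay, with a stated time of 48 h, tested at 10 uM (on this read-out lower numbers stand for less inhibition and higher numbers for more inhibition at the one concentration tested (going by the name of the read-out)), compound 1 gives 5.11%, and compound 2 gives 0.55%, the lowest of the two numbers, with the gap to compound 1 lying within the scatter. Compound 3 `O=Cc1ccc(-c2cn3ccnc3c(-c3ccc4ncn(Cc5ccccc5)c4c3)n2)cc1` has not been measured. From compound 2 to compound 3 the change is formyl in place of ethyl on an aromatic carbon. Compound 1 also carries a formyl group, and in this assay compound 1 with its 5.11% sits within the scatter of compound 2. The expected step is therefore a number 3.5 percentage points higher from compound 2 to compound 3 (within the scatter), none beyond the scatter. For compound 3 in this assay the estimate is 4%, ranging from -8% to 16%.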

Compound 3, a percentage reported as inhibition, at one concentration (the size of the read-out at that concentration, not a potency): 5.11%
The estimate for compound 3 lay 1.1 percentage points below the measured number; the range from low to high includes it.
By their numbers in this assay, from the lowest: compounds 2, 1 and 3 (each within the scatter of the next).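

In this assay, the change from 4-ethylphenyl to 4-formylphenyl on the benzyl compound gives a number 4.6 percentage points higher from compound 2 to compound 3 (within the scatter), so this exchange on the aromatic carbon stays inside the noise. Among the compounds shown here, with formyl held fixed, benzyl in place of cyclohexyl on the aromatic nitrogen gives no change at the digits printed from compound 1 to compound 3 (within the scatter), which for the first time isolates that second place and shows no separation there either. No supporting data bear on why these pairs read alike.

Open, on these data alone, is whether an amine or a carboxylic acid in place of formyl would separate from these compounds. A longer chain on the aromatic nitrogen is equally untested among the compounds shown.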